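Aryl Exchange on a Triazole Nitrogen at the Assay Limit

This account rests on a few compounds, and the source may have more. Where it says the series, first, only, none or still open, it means among the compounds named here.

Compound 1 `COc1ccc(-n2nncc2CN2C(=O)C3(C(C#N)=C(N)Oc4c(N)cc5nc6ccccc6nc5c43)c3ccccc32)cc1` in an ADME assay on L02 cells (Homo sapiens) for antiproliferative activity, read by MTT assay, with a stated time of 48 h (on this read-out higher numbers stand for weaker inhibition and lower numbers for stronger inhibition), gives > 50000 nM, a limit of the assay. Compound 2 `CCOc1ccccc1-n1nncc1CN1C(=O)C2(C(C#N)=C(N)Oc3c(N)cc4nc5ccccc5nc4c32)c2ccccc21` gives > 50000 nM, again a limit. Compound 3 `CCc1cccc(CC)c1-n1nncc1CN1C(=O)C2(C(C#N)=C(N)Oc3c(N)cc4nc5ccccc5nc4c32)c2ccccc21` gives > 50000 nM, likewise a limit.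

Compound 3 therefore stands where every measured compound stands, at the limit (the limit of > 50000 nM in this assay, at which 3 of the 3 values shown sit), and no number is known for it. The steps a step that the two limits leave unreadable from compound 1 to compound 2, a step that the two limits leave unreadable from compound 1 to compound 3 and a step that the two limits leave unreadable from compound 2 to compound 3 are all unreadable, since both ends of each sit at that limit. Compound 4 `COc1ccc(OC)c(-n2nncc2CN2C(=O)C3(C(C#N)=C(N)Oc4c(N)cc5nc6ccccc6nc5c43)c3ccccc32)c1` carries the change (2,5-dimethoxyphenyl in place of 2,6-diethylphenyl on an aromatic nitrogen). For the measured compounds named here, no measured step bears readably on this change, and no step beyond the scatter is expected; the step of a number no higher from compound 3 to compound 4 (the limit leaves the size open) is estimated to leave compound 4 at the limit. Compound 4 is thus expected at 50000 nM, within 20000 nM to 200000 nM.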

Compound 4, half-maximal inhibitory concentration: > 50000 nM
Compound 4: no number, only a limit; the forecaster's own chance of this, stated with the estimate: 90%; the middle value sits exactly at the limit.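

No new step can be read between compound 4 and compound 1, compound 2 or compound 3, as all four share one limit: the limit of > 50000 nM in this assay, at which 4 of the 4 values shown sit.

The compounds shown leave open how the aryl group on the aromatic nitrogen bears on inhibition, since none of them has a number.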